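Methoxy for Methyl on the Aryl of Compound 1

The compounds below may be only part of what the source reports. "The series", "measured", "known", "first", "only" and "open" are said of these compounds alone.

Compound 1 `C=C(Br)C(=O)Nc1cccc(-c2cn3nc(-c4ccc(C)cc4)sc3n2)c1` gives the lowest number of the three measured in a functional assay on FM3A cells (Mus musculus) for inhibition, read by cell counting, with a stated time of 2 days (on this read-out higher numbers stand for weaker inhibition and lower numbers for stronger inhibition), at 1200 nM. Compound 2 `COc1ccc(-c2csc3nc(-c4cccc(N)c4)cn23)cc1` gives 11000 nM and compound 3 `Nc1cccc(-c2cn3c(-c4ccccc4)csc3n2)c1` gives 34000 nM, so compound 1 sits well clear of both. Among the compounds with values here, the only single-point step among them, a 3.1-fold higher number from compound 2 to compound 3 (0.49 log units; beyond the scatter), concerns hydrogen in place of methoxy on an aromatic carbon. Compound 4 `C=C(Br)C(=O)Nc1cccc(-c2cn3nc(-c4ccc(OC)cc4)sc3n2)c1` differs from compound 1 by methoxy in place of methyl on an aromatic carbon. Within the data shown here, no measured step compares methoxy with methyl directly; the step from compound 2 to compound 3 hints that methoxy may help somewhat, though on a different core. Compound 4 is therefore expected to show a small step of a 1.5-fold lower number from compound 1 to compound 4 (0.18 log units; within the scatter), near the scatter, toward stronger inhibition. The estimate for compound 4 is 800 nM, with a range from 300 nM to 2500 nM.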

Compound 4, half-maximal inhibitory concentration: 890 nM
The estimate for compound 4 lay 1.1-fold (0.05 log units) below the measured number; the measured number falls inside the stated range.
By their numbers in this assay, from the lowest: compounds 4 and 1 (each within the scatter of the next); then compound 2; then compound 3.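

In this assay, the change from 4-methylphenyl to 4-methoxyphenyl gives a 1.3-fold lower number from compound 1 to compound 4 (0.13 log units; within the scatter), so the two groups cannot be told apart at this position on the core of compound 1. The earlier step, a 3.1-fold higher number from compound 2 to compound 3 (0.49 log units; beyond the scatter), set methoxy against hydrogen on a different core and offered no direct comparison with methyl. No available evidence bears on this result. On these data alone, what remains open is how an amine, a carboxylic acid or a longer chain would read at this position. Also open, as far as these compounds go, is whether hydrogen there would repeat the earlier step on this core.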